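A Phenylethenyl Arm Replaces the Substituted Phenyl

The source may hold more compounds than are shown below. What is called first, only, known or untested is meant among the compounds shown, and "the series" means these compounds.

Three compounds share one core and differ only in the group attached at a single aromatic carbon of the ring that carries the ring nitrogen. In an assay on CHO cells for antagonist activity at transient receptor potential cation channel subfamily V member 1 (Homo sapiens), read by FLIPR (a higher number here means a weaker inhibitor, a lower number a stronger inhibitor), compound 1 `Cc1cc(-c2nc(C(F)(F)F)ccc2CNC(=O)C(C)c2ccc(NS(C)(=O)=O)c(F)c2)ccc1F` gives 0.4 nM. Compound 2 `CC(C(=O)NCc1ccc(C(F)(F)F)nc1-c1ccc(Cl)c(Cl)c1)c1ccc(NS(C)(=O)=O)c(F)c1` gives 0.9 nM in this assay, and compound 3 `COc1ccc(-c2nc(C(F)(F)F)ccc2CNC(=O)C(C)c2ccc(NS(C)(=O)=O)c(F)c2)cc1F` gives 4.2 nM. Compound 3 therefore stands highest of the three and is the weakest inhibitor: an 11-fold higher number from compound 1 to compound 3 (1.02 log units; beyond the scatter), and a 4.7-fold higher number from compound 2 to compound 3 (0.67 log units; beyond the scatter), both beyond the scatter. Compound 4 `CC(C(=O)NCc1ccc(C(F)(F)F)nc1/C=C/c1ccccc1)c1ccc(NS(C)(=O)=O)c(F)c1` changes the same position once more: 2-phenylethenyl in place of 3-fluoro-4-methoxyphenyl on an aromatic carbon. For the measured compounds named here, no measured step involves a 2-phenylethenyl group, so nothing bears on it directly; the steps at this position only show how much the number can move when this group is exchanged: a 2.3-fold higher number from compound 1 to compound 2 (0.35 log units; beyond the scatter), and an 11-fold higher number from compound 1 to compound 3 (1.02 log units; beyond the scatter). Losing the one hydrogen-bond acceptor and the fluorine is expected to cost a little, so for compound 4 a small upward step is expected, a 1.4-fold higher number from compound 3 to compound 4 (0.15 log units; within the scatter). Compound 4 is estimated at 6 nM, with a range from 1.2 nM to 30 nM.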

Compound 4, inhibition constant: 2.2 nM
For compound 4 the middle estimate is 2.7-fold (0.44 log units) above the measured one; measured number inside the range.
By their numbers in this assay, from the lowest: compound 1; then compound 2; then compounds 4 and 3 (each within the scatter of the next).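

Compound 4 shows that this position does not need a substituted phenyl ring attached directly to the aromatic carbon: 2-phenylethenyl brings an unsubstituted ring with a double bond outside aromatic rings, and it has no hydrogen-bond acceptor, yet in this assay the exchange for 3-fluoro-4-methoxyphenyl gives only a small change (a 1.9-fold lower number from compound 3 to compound 4 (0.28 log units; within the scatter)). The new group still falls short of the two compounds with the lowest numbers, as the steps (a 2.4-fold higher number from compound 2 to compound 4 (0.39 log units; beyond the scatter)) and (a 5.5-fold higher number from compound 1 to compound 4 (0.74 log units; beyond the scatter)) show. Nothing available here explains these differences.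

The compounds shown leave open whether the double bond matters in itself, a question that a saturated 2-phenylethyl chain would address. As far as these compounds go, it is also open whether chlorine or fluorine on the ring of the 2-phenylethenyl group would move the number as far as the differences among the directly attached rings.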